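A few compounds are considered here, and "the series" means these few. Any claim that something is new, unique, unknown or untested is made for them only; others in the source may bear on it.

Compound 1 `CCOC(=O)c1nn(-c2ccc(OCC)cc2)cc1O` carries an ethyl on an oxygen next to a carbonyl group; in an assay on isolated protein for inhibition of patatin-like phospholipase domain-containing protein 2 (Mus musculus) (on this read-out higher numbers stand for weaker inhibition and lower numbers for stronger inhibition), compound 1 gives 120000 nM. Compound 2 `CCOc1ccc(-n2cc(O)c(C(=O)O)n2)cc1` differs from it only in that a hydrogen replaces that ethyl. In this assay compound 2 reaches only a limit of the measurement, > 200000 nM, so its true value is not known as a number. The step from the ethyl to the hydrogen, an at least 1.6-fold higher number from compound 1 to compound 2 (0.22 log units; that floor lies within the scatter), therefore rests on a limit, (the limit of > 200000 nM in this assay, at which 1 of the 2 values shown sits), and its size may be larger than the floor that can be stated.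

Compound 3 `CCOc1ccc(-n2cc(O)c(C(=O)OC)n2)cc1` has not been measured. The change from compound 2 to compound 3 is methyl in place of hydrogen on an oxygen next to a carbonyl group. Within the data shown here, the only measured step that bears on this change runs the other way, from an ethyl to a hydrogen, and it weakened inhibition by at least the amount given in that step. Putting a small alkyl back onto the same oxygen is expected to undo at least part of that loss, so compound 3 is expected to land near compound 1 rather than at the limit, a step of an at least 1.5-fold lower number from compound 2 to compound 3 (0.18 log units; that floor lies within the scatter), with an estimate of 130000 nM and a range from 50000 nM to 300000 nM.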

Compound 3, half-maximal inhibitory concentration: 130000 nM
Compound 3: middle estimate and measured number agree at the digits printed; the measured number falls inside the stated range.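

Shortening the ethyl to a methyl on this oxygen gives no readable difference in this assay, with a 1.1-fold higher number from compound 1 to compound 3 (0.03 log units; within the scatter), so the two small alkyl groups cannot be told apart here. Going from hydrogen to methyl gives an at least 1.5-fold lower number from compound 2 to compound 3 (0.18 log units; that floor lies within the scatter), which is the earlier ethyl-to-hydrogen comparison seen from a second alkyl group, and both alkyl compounds return a number on this read-out while the hydrogen compound does not. Even so, the floor of this step lies within the scatter, and its true size stays unknown because compound 2 sits at a limit: the limit of > 200000 nM in this assay, at which 1 of the 3 values shown sits.

The compounds shown leave open what a longer chain such as butyl, or a benzyl, would do on this oxygen, and whether the oxygen itself matters, which an amide with a nitrogen in its place would test. They also leave open how far the carboxy compound truly lies from the two alkyl compounds, since only a number in place of its limit could settle that gap.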